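Methoxy Added to a Benzamide and to a Fused Core

A few compounds are considered here, and "the series" means these few. Any claim that something is new, unique, unknown or untested is made for them only; others in the source may bear on it.

Compound 1 `O=C(Nc1ccc(Cl)cc1F)c1ccccc1` and compound 2 `COc1ccc(C(=O)Nc2ccc(Cl)cc2F)cc1` share one core and differ by methoxy in place of hydrogen on an aromatic carbon. In an ADME assay on RAW264.7 cells (Mus musculus) for cytotoxicity, read by MTT assay, with a stated time of 24 h (a lower number here means that less compound is tolerated, a higher number that more compound is tolerated), compound 1 gives only a limit of the assay, > 40000 nM. Compound 2 likewise gives only a limit, > 40000 nM. The step that the two limits leave unreadable from compound 1 to compound 2 is accordingly not readable. Compound 3 `O=c1oc2ccccc2c(=O)n1-c1ccc(F)cc1F` rests on another core; the difference between the two cores is not broken down here. Compound 3 also gives only a limit, > 40000 nM. Compound 4 `COc1ccc2c(=O)n(-c3ccc(F)cc3F)c(=O)oc2c1` differs from compound 3 by methoxy in place of hydrogen on an aromatic carbon, the same kind of change as before, though here the place is a six-membered aromatic ring of carbon only, part of a fused or bridged system of two rings, meta to a fused ring and para to a fused ring, rather than a ring para to a large group. Because (the limit of > 40000 nM in this assay, at which 3 of the 3 values shown sit), compound 4 is expected to show a step that the limit leaves unreadable from compound 3 to compound 4 of no real size. Compound 4 is estimated at 60000 nM, most likely again only a limit.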

Compound 4, half-maximal cytotoxic concentration: > 40000 nM
Compound 4: no number, only a limit (the forecaster's own chance of this, stated with the estimate: 85%); the middle value does not contradict the limit.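

No step can be read from compound 3 to compound 4, because both give only a limit: the limit of > 40000 nM in this assay, at which 4 of the 4 values shown sit.

The compounds shown leave open whether methoxy in place of hydrogen shifts cytotoxicity on either core, and at what concentration any of them becomes cytotoxic.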